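Ester for aryl on the triazole: cytotoxicity step to compound 4

This account rests on a few compounds, and the source may have more. Where it says the series, first, only, none or still open, it means among the compounds named here.

Measured compounds:
compound 1, `COc1nc2ccc(Br)cc2cc1C(c1ccccc1)n1cc(-c2ccccc2F)nn1`: 14.1%
compound 2, `COc1nc2ccc(Br)cc2cc1C(c1ccccc1)n1cc(-c2ccc(Br)cc2)nn1`: 6.92%
compound 3, `COc1nc2ccc(Br)cc2cc1C(c1ccccc1)n1cc(-c2ccccc2C(F)(F)F)nn1`: -1.3%

Three compounds sharing one core were tested in an ADME assay on HeLa cells (Homo sapiens) for cytotoxicity, read by sulforhodamine B assay, with a stated time of 48 h, tested at 10 uM; on this read-out higher numbers stand for more inhibition at the one concentration tested (going by the name of the read-out) and lower numbers for less inhibition. Compound 1 gives 14.1%, the highest of the three numbers. Compound 2 gives 6.92%, and the step of a number 7.2 percentage points lower from compound 1 to compound 2 (within the scatter) is within the scatter. Compound 3 gives -1.3%, and the step of a number 15.4 percentage points lower from compound 1 to compound 3 (beyond the scatter) is beyond the scatter, while the step of a number 8.2 percentage points lower from compound 2 to compound 3 (within the scatter) is within it. All three numbers are small on this read-out.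

Compound 4, `CCOC(=O)c1cn(C(c2ccccc2)c2cc3cc(Br)ccc3nc2OC)nn1`, has not yet been measured in this assay. It differs from compound 1 in one place: ethoxycarbonyl in place of 2-fluorophenyl on an aromatic carbon. Among the measured compounds shown here, none of the measured steps exchanges an aromatic ring for a non-ring group, so no step bears directly on this change; the measured steps only show that swapping groups at this position moved the read-out by small to modest amounts. Compound 4 is therefore expected to stay near the low values seen, with an expected step of a number 8.1 percentage points lower from compound 1 to compound 4 (within the scatter) that does not clearly exceed the scatter. Compound 4 is estimated at 6%, within -8% to 20%.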

Compound 4, a percentage reported as inhibition, at one concentration (the size of the read-out at that concentration, not a potency): -3.67%
Estimate against measurement, compound 4: 9.7 percentage points above, within the range that was stated.
By their numbers in this assay, from the lowest: compounds 4, 3, 2 and 1 (each within the scatter of the next, the first and the last beyond it).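

In this assay, among the compounds shown here, the first group without a ring at this place on the five-membered aromatic ring, ethoxycarbonyl, gives a number 17.8 percentage points lower from compound 1 to compound 4 (beyond the scatter) and a number 10.6 percentage points lower from compound 2 to compound 4 (beyond the scatter), both modest steps, so replacing either 2-fluorophenyl or 4-bromophenyl with it takes the read-out to around zero rather than raising it. Against the third aryl group, 2-(trifluoromethyl)phenyl, there is only a number 2.4 percentage points lower from compound 3 to compound 4 (within the scatter), so an aromatic ring at this place is not needed for a number this low. Nothing available explains these differences.

As far as these compounds go, it remains open whether a carboxylic acid, an amine or a longer alkyl chain at this place would read like ethoxycarbonyl or like 2-fluorophenyl. From the compounds shown here alone, it is also open whether any group here can lift the read-out clear of the small numbers seen so far.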